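The source may report more compounds than this note shows. Statements on the series, on what has been measured and on what is new or still open speak of the compounds shown alone.

Compound 1 `O=C1c2ccc(OCc3cccc(-c4ccc(Cl)cc4F)c3)cc2CN1C1CCCC1`, compound 2 `COc1ccc(C(=O)O)cc1-c1cccc(COc2ccc3c(c2)CN(C2CCCC2)C3=O)c1` and compound 3 `O=C(O)c1ccc(Cl)c(-c2cccc(COc3ccc4c(c3)CN(C3CCCC3)C4=O)c2)c1` share one core and differ in the group on an aromatic carbon. In an ADME assay on microsomes from liver (Rattus norvegicus) for metabolic stability, read by LC-MS, with a stated time of 1 h, at 37 degrees C, tested at 4 uM (on this read-out higher numbers stand for a more stable compound and lower numbers for a less stable compound), the entry for compound 1 reads "not determined" (no result reported), compound 2 gives 30% and compound 3 gives 15%. Compound 3 thus holds the lower of the two numbers available. Compound 4 `O=C(O)c1cc(F)cc(-c2cccc(COc3ccc4c(c3)CN(C3CCCC3)C4=O)c2)c1` differs from compound 3 as follows: 3-carboxy-5-fluorophenyl in place of 5-carboxy-2-chlorophenyl on an aromatic carbon. Going by the values given here, the 3-carboxy-5-fluorophenyl group sits meta to a large group, and no measured compound carries it. Among the compounds with values here, only one measured step bears on the change: a number 15 percentage points lower from compound 2 to compound 3 (beyond the scatter), with chloro in place of methoxy on an aromatic carbon. Compound 4 has no chloro, so that step offers a rough guide to the size of the change and suggests a rise, though it says nothing directly about the fluorine. In this assay, within the data shown here, a modest rise no larger than that step is therefore expected, namely a number 11 percentage points higher from compound 3 to compound 4 (beyond the scatter). For compound 4 the estimated value is 26%, with an expected range from 10% to 45%.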

Compound 4, percent of the compound remaining: 55%
Compound 4: the middle estimate sits 29 percentage points below what was measured; the whole stated range lies below it.
By their numbers in this assay, from the lowest: compound 3; then compound 2; then compound 4.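

At this aromatic carbon, 3-carboxy-5-fluorophenyl in place of 5-carboxy-2-chlorophenyl gives a number 40 percentage points higher from compound 3 to compound 4 (beyond the scatter) in this assay and so shows a larger swing at this position than the earlier swap of methoxy for chloro did. The same group in place of 5-carboxy-2-methoxyphenyl gives a number 25 percentage points higher from compound 2 to compound 4 (beyond the scatter) in this assay and places compound 4 clear of both earlier numbers, so a ring bearing a carboxylic acid is compatible with a higher number here. Nothing at hand accounts for this rise.

The carboxy group's new place, the loss of chloro or methoxy and the arrival of fluoro all come together, and the compounds shown do not separate them. They also leave open whether a primary amide or a nitrile in place of the carboxylic acid would hold the number.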